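The source may hold more compounds than are shown below. What is called first, only, known or untested is meant among the compounds shown, and "the series" means these compounds.

Measured so far:
compound 1, `N#CC1=C(N)OC(c2c[nH]c3ccccc23)=C(C#N)C1c1ccc(F)cc1` — 8.4%
compound 2, `N#CC1=C(N)OC(c2c[nH]c3ccccc23)=C(C#N)C1c1ccc(Br)cc1` — 14.2%

Compound 1 is `N#CC1=C(N)OC(c2c[nH]c3ccccc23)=C(C#N)C1c1ccc(F)cc1`; in a functional assay, tested at 50 ug/mL (on this read-out lower numbers stand for a weaker effect and higher numbers for a stronger effect at the one concentration tested), compound 1 gives 8.4%. Compound 2, `N#CC1=C(N)OC(c2c[nH]c3ccccc23)=C(C#N)C1c1ccc(Br)cc1`, gives 14.2% in this assay. Of the two numbers, compound 1 is the lower, but the gap to compound 2 is small: a number 5.8 percentage points higher from compound 1 to compound 2 (within the scatter), so the two are not told apart.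

Compound 3 is `Cc1ccccc1C1C(C#N)=C(N)OC(c2c[nH]c3ccccc23)=C1C#N`. It differs from compound 1 in one place: 2-methylphenyl in place of 4-fluorophenyl on a saturated ring carbon. Within the data shown here, the only measured step, bromo in place of fluoro on an aromatic carbon, stayed within the scatter and concerns another exchange on the same ring, so it bears on this step only loosely. Among the measured compounds shown here, no measured pair shows what replacing 4-fluorophenyl by 2-methylphenyl does.

With both measured numbers close together, compound 3 is expected to stay near them, an estimated step of a number 2.6 percentage points higher from compound 1 to compound 3 (within the scatter). The estimate for compound 3 in this assay is 11%, within 3% to 22%.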

Compound 3, a percentage reported as activity, at one concentration (the size of the read-out at that concentration, not a potency): 10.4%
Compound 3: the middle estimate sits 0.6 percentage points above what was measured; the range from low to high includes it.
By their numbers in this assay, from the lowest: compounds 1, 3 and 2 (each within the scatter of the next).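

In this assay, the saturated ring carbon now carries an aryl group with a methyl rather than a halogen, and 2-methylphenyl in place of 4-fluorophenyl gives a number 2 percentage points higher from compound 1 to compound 3 (within the scatter) while 2-methylphenyl in place of 4-bromophenyl gives a number 3.8 percentage points lower from compound 2 to compound 3 (within the scatter). The earlier pair varied only the halogen on the phenyl group, whereas this result shows that exchanging the whole substituted phenyl group at this carbon also leaves the read-out unresolved, so the three compounds are not told apart. No independent measurement is available to account for this result.

As far as these compounds go, all three compounds keep a substituted phenyl group at this carbon, so it remains open whether an amine, a carboxylic acid or a longer alkyl chain there would give a read-out beyond the scatter. From the compounds shown here alone, the contribution of the 1H-indol-3-yl group and the two cyano groups also remains open.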